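Trading a Fluorinated Ring for a Carboxy-Bearing One

This account rests on a few compounds, and the source may have more. Where it says the series, first, only, none or still open, it means among the compounds named here.

In an assay on HEK293 cells for positive allosteric modulation of metabotropic glutamate receptor 2 (Rattus norvegicus), read by thallium flux (a lower number here means that less compound is needed, a higher number that more compound is needed for the effect), compound 2 `O=C1c2ccc(OCc3cccc(-c4ccc(C(F)(F)F)cc4F)c3)cc2CN1C1CCCC1` gives only a limit, > 5000 nM. Because (the limit of > 5000 nM in this assay, at which 1 of the 3 values shown sits), compound 2 has no number of its own to set against the others. Among the measured compounds shown here, compound 1 `O=C(O)c1cc(-c2cccc(COc3ccc4c(=O)n(C5CCC5)sc4c3)c2)ccc1Cl` gives 580 nM and compound 3 `CC(C)Cn1sc2cc(OCc3cccc(-c4ccc(Cl)c(C(=O)O)c4)c3)ccc2c1=O` gives 470 nM in this assay; the single measured step, a 1.2-fold lower number from compound 1 to compound 3 (0.09 log units; within the scatter), concerns the group on the ring nitrogen and does not touch the change at hand. Compound 4 `Cc1ccc(C(=O)O)cc1-c1cccc(COc2ccc3c(c2)CN(C2CCCC2)C3=O)c1` differs from compound 2 by 5-carboxy-2-methylphenyl in place of 2-fluoro-4-(trifluoromethyl)phenyl on an aromatic carbon. For the measured compounds named here, no measured step bears directly on it, but compound 1 and compound 3 also carry a carboxy group and both give numbers rather than limits. Compound 4 is therefore expected to give about 800 nM, within 300 nM to 2500 nM. That estimate amounts to an expected step of an at least 6.2-fold lower number from compound 2 to compound 4 (0.79 log units; beyond the scatter).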

Compound 4, half-maximal effective concentration: 110 nM
Compound 4: middle estimate off by 7.3-fold (0.86 log units), on the high side; the whole stated range lies above it.
By their numbers in this assay, from the lowest: compound 4; then compounds 3 and 1 (each within the scatter of the next). At a limit, above all of these: compound 2.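

On this aromatic carbon, meta to a large group, 5-carboxy-2-methylphenyl in place of 2-fluoro-4-(trifluoromethyl)phenyl gives a large step in this assay: an at least 45-fold lower number from compound 2 to compound 4 (1.65 log units; beyond the scatter). Compounds 1 and 3 carry a carboxy group on another core, whereas this pair reads the ring change on one core. The full size of the step stays unknown, as it starts from a limit, not a number: the limit of > 5000 nM in this assay, at which 1 of the 4 values shown sits.

The carboxy and methyl groups enter together, and the compounds shown do not separate them. Going by these compounds, whether a primary amide or a nitrile could stand in for the carboxylic acid also remains open.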